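A few compounds are considered here, and "the series" means these few. Any claim that something is new, unique, unknown or untested is made for them only; others in the source may bear on it.

Working notes on the series.

The shared core is seen in compound 3 `O=C(Nc1cccc([N+](=O)[O-])c1)c1c(O)c2cccnc2n(-c2ccccc2)c1=O`, which carries a 3-nitrophenyl on the amide-type nitrogen. For the measured compounds named here, in a functional assay on the whole organism for inhibition, with Rattus norvegicus as the target, read by cytopathic effect and paw edema, at a dose of 100 mg/kg by the oral route (a lower number here means less inhibition, a higher number more inhibition at the dose given (going by the name of the read-out)), compound 3 gives 7.4%, the highest of the three numbers so far, although compound 1 `Cc1ccc(NC(=O)c2c(O)c3cccnc3n(-c3ccccc3)c2=O)cc1` with 2.2% lies within the scatter of it, so no order between those two is claimed. Compound 2 `O=C(Nc1ccc([N+](=O)[O-])cc1)c1c(O)c2cccnc2n(-c2ccccc2)c1=O` gives -25.8% in this assay and stands clearly apart: a number 33.2 percentage points higher from compound 2 to compound 3 (beyond the scatter), and a number 28 percentage points lower from compound 1 to compound 2 (beyond the scatter), whereas a number 5.2 percentage points higher from compound 1 to compound 3 (within the scatter).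

Compound 4 `COc1ccc(NC(=O)c2c(O)c3cccnc3n(-c3ccccc3)c2=O)cn1` is not yet measured. Its change from compound 3: 6-methoxypyridin-3-yl in place of 3-nitrophenyl on an amide-type nitrogen. Going by the values given here, two measured steps involve a swap of the ring on the amide-type nitrogen, one within the scatter and one large, so the numbers so far span from the value of compound 2 to that of compound 3, and a new ring may land anywhere in that span. Among the compounds with values here, no measured compound carries a pyridine or a methoxy, so the direction is open; compound 3 holds the top of the span, so a fall is somewhat more likely than a rise in this assay. The expected step is a number 7.4 percentage points lower from compound 3 to compound 4 (within the scatter), expected to stay within the scatter. The estimate for compound 4 in this assay is 0%, expected to fall between -27% and 22%.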

Compound 4, a percentage reported as inhibition, in the whole organism at one dose (the size of the read-out at that dose, not a potency): -10.2%
Compound 4: the middle estimate sits 10.2 percentage points above what was measured; measured number inside the range.
By their numbers in this assay, from the lowest: compound 2; then compound 4; then compounds 1 and 3 (each within the scatter of the next).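

In this assay, the 6-methoxypyridin-3-yl on the amide-type nitrogen brings the first ring with a hetero atom to this place, and the result separates from all three earlier rings: a number 17.6 percentage points lower from compound 3 to compound 4 (beyond the scatter), a number 12.4 percentage points lower from compound 1 to compound 4 (beyond the scatter), and a number 15.6 percentage points higher from compound 2 to compound 4 (beyond the scatter). The ring at this place now gives three separate levels rather than one outlying compound and a pair, with compound 4 at -10.2% sitting under compound 1 and compound 3, which remain unordered, and over compound 2. Nothing available bears on the reason for this placement.

The pyridine nitrogen and the methoxy enter together, so the compounds shown do not assign the step to either one, and a 4-methoxyphenyl or an unsubstituted pyridin-3-yl at this place would separate the two. Also open is whether a ring carrying an amine or a carboxylic acid would rise clearly above compound 3 in this assay, since no ring shown here gives a number beyond the scatter of compound 1 and compound 3 on the upper side.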